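A few compounds are considered here, and "the series" means these few. Any claim that something is new, unique, unknown or untested is made for them only; others in the source may bear on it.

Compound 1, `CS(=O)(=O)Nc1ccc2oc(-c3ccccc3)nc2c1`: > 100000 nM
Compound 2, `COc1ccccc1S(=O)(=O)Nc1ccc2oc(-c3ccccc3)nc2c1`: 41000 nM

In an ADME assay on HEK293 cells (Homo sapiens) for cytotoxicity, read by resazurin assay, with a stated time of 48 h (a lower number here means that less compound is tolerated, a higher number that more compound is tolerated), compound 1 gives only a limit of the assay, > 100000 nM. Among the measured compounds shown here, compound 2 is the one compound with an actual number, 41000 nM. The other value shown, that of compound 1, is a limit, as described by the limit of > 100000 nM in this assay, at which 1 of the 2 values shown sits. For the measured compounds named here, the step of an at least 2.4-fold lower number from compound 1 to compound 2 (0.38 log units; beyond the scatter) is the single measured change, and it is at least modest.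

Compound 3, `O=S(=O)(Nc1ccc2oc(-c3ccccc3)nc2c1)c1ccc(Cl)s1`, is not yet measured. It differs from compound 2 in one place: 5-chlorothiophen-2-yl in place of 2-methoxyphenyl on a sulfonyl sulfur. Going by the values given here, the only measured step exchanged a methyl for an aromatic ring on the sulfonyl sulfur, whereas here one aromatic ring replaces another; that step therefore bears on this change only loosely, and no step beyond the usual scatter is expected in this assay. Compound 3 is estimated at 30000 nM, between 10000 nM and 90000 nM, meaning an expected step of a 1.4-fold lower number from compound 2 to compound 3 (0.14 log units; within the scatter).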

Compound 3, half-maximal cytotoxic concentration: > 100000 nM
Compound 3: only a limit was reported (the forecaster's own chance of this, stated with the estimate: 15%); at least 3.3-fold (0.52 log units) between middle value and limit.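

The earlier pair showed only that 2-methoxyphenyl on the sulfonyl sulfur gives a lower number than methyl, which might have suggested that any aromatic ring there would do the same. In this assay, the exchange of 2-methoxyphenyl for 5-chlorothiophen-2-yl gives an at least 2.4-fold higher number from compound 2 to compound 3 (0.38 log units; beyond the scatter), so the presence of an aromatic ring at this place does not by itself bring a lower number: which ring stands there matters. The step between the two remaining compounds cannot be read, since both values are limits: the limit of > 100000 nM in this assay, at which 2 of the 3 values shown sit.

Going by these compounds, whether the lower number of compound 2 comes from its methoxy group or from its phenyl ring stays open. Also open, on these data alone, is what an unsubstituted phenyl, or a phenyl carrying an amine or a carboxylic acid, would give on the sulfonyl sulfur.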